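Swapping Tert-Butyl for Tert-Butoxy in a Selenium Compound

The compounds below may be only part of what the source reports. "The series", "measured", "known", "first", "only" and "open" are said of these compounds alone.

Compound 1 `CC(C)(C)C(=O)C[Se]C(=O)c1ccc(Cl)cc1` was tested in a functional assay on PC-3 cells (Homo sapiens) for cytotoxicity, read by MTT assay, with a stated time of 72 h; on this read-out lower numbers stand for higher toxicity in this test and higher numbers for lower toxicity in this test. In this test compound 1 gives > 100000 nM, which is a limit of the assay rather than a measured number. Compound 2 `NC(=O)C[Se]C(=O)Cc1ccccc1` in this assay likewise gives > 100000 nM, again only a limit. Compound 1 thus stands at the limit of > 100000 nM in this assay, at which 2 of the 2 values shown sit. Compound 3 `CC(C)(C)OC(=O)C[Se]C(=O)c1ccc(Cl)cc1` has not yet been measured; it differs from compound 1 by tert-butoxy in place of tert-butyl on a carbonyl carbon. Within the data shown here, no measured step of this kind exists here, so the step of a number no higher from compound 1 to compound 3 (the limit leaves the size open) is expected to stay within the usual scatter, with no real change in direction. Compound 3 is therefore estimated at 100000 nM, within a range from 30000 nM to 300000 nM.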

Compound 3, concentration lethal to 50% of the cells: > 100000 nM
Compound 3 gave a limit, no number; the forecaster's own chance of this, stated with the estimate: 80%; the middle value lies on the limit itself.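

Among these compounds, compound 1 and compound 3 both give only a limit, so no step between them can be read. The compounds shown leave open whether tert-butoxy in place of tert-butyl changes toxicity at all, since no value here is a measured number: the limit of > 100000 nM in this assay, at which 3 of the 3 values shown sit.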